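The compounds below may be only part of what the source reports. "The series", "measured", "known", "first", "only" and "open" are said of these compounds alone.

In an ADME assay on microsomes from liver (Homo sapiens) for metabolic stability, with a stated time of 10 min, tested at 0.5 uM (on this read-out higher numbers stand for a more stable compound and lower numbers for a less stable compound), compound 1 `Cn1cc(-c2ccc(C(F)(F)F)cc2)c2cc(F)c(C(=O)NS(=O)(=O)C3CC3)cc21` gives 100% and compound 2 `CC(C)COc1ncc(-c2cn(C)c3cc(C(=O)NS(=O)(=O)C4CC4)c(F)cc23)cc1Cl` gives 100% as well, so compound 2 shares the top of the three measured numbers with compound 1. Compound 3 `Cn1cc(-c2ccc(C(F)(F)F)cc2)c2ccc(C(=O)NS(=O)(=O)C3CC3)cc21` gives 87% and lies lower than both.

Compound 4 `CC(C)COc1ncc(-c2cn(C)c3cc(C(=O)NS(C)(=O)=O)c(F)cc23)cc1Cl` differs from compound 2 by methyl in place of cyclopropyl on a sulfonyl sulfur. Going by the values given here, no measured step covers this change. Among the compounds with values here, the only step available, a number 13 percentage points lower from compound 1 to compound 3 (beyond the scatter) with hydrogen in place of fluoro on an aromatic carbon, sits at another place in the structure and gives only a rough size for one change. Compound 4 keeps the fluoro of compound 2.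

No shift beyond the scatter is expected, and a slight drop is more likely than a rise, since compound 2 gives 100% already. An estimated step of a number 5 percentage points lower from compound 2 to compound 4 (within the scatter) is expected in this assay on this basis. Compound 4 is estimated at 95% (expected range 83% to 100%).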

Compound 4, percent of the compound remaining: 100%
Compound 4: the middle estimate sits 5 percentage points below what was measured; measured number inside the range.
By their numbers in this assay, from the lowest: compound 3; then compounds 1, 2 and 4 (each within the scatter of the next).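

In this assay, the sulfonyl sulfur gets its first measured change, and methyl in place of cyclopropyl gives no change at the digits printed from compound 2 to compound 4 (within the scatter). The cyclopropyl ring is therefore not required at this position to keep this read-out at the top of the percent scale, at least on the core of compound 2, although a value at the top of the scale cannot show a gain, and a small loss could stay hidden within the scatter. Nothing measured here gives a reason for this result.

From the compounds shown here alone, it remains open whether a phenyl ring or a dimethylamino group on the same sulfonyl sulfur would leave the read-out unchanged. Also open, going by these compounds, is how methyl in place of cyclopropyl behaves on the core of compound 3, which has more room to move at 87%.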